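Sulfanyl substituent change on the benzimidazole-bearing piperidine series

This account rests on a few compounds, and the source may have more. Where it says the series, first, only, none or still open, it means among the compounds named here.

Measured compounds:
- compound 1: `O=C(CCCN1CCC(n2cnc3ccccc32)CC1)c1ccc(F)cc1` gives 4.7 mg/kg
- compound 2: `O=C(CCCN1CCC(n2c(Sc3ccccc3[N+](=O)[O-])nc3ccccc32)CC1)c1ccc(F)cc1` gives 11 mg/kg

The read-out is a functional assay on the whole organism (strain STD-ddY) for inhibition, with Mus musculus as the target, with a stated time of 5 min; a higher number here means that more compound is needed for the effect, a lower number that less compound is needed. Within these two numbers compound 2 stands at the higher end, with compound 1 the only comparison; the step of a 2.3-fold higher number from compound 1 to compound 2 (0.37 log units; beyond the scatter) is beyond the scatter and corresponds to (2-nitrophenyl)sulfanyl in place of hydrogen on an aromatic carbon.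

Compound 3, `CCOC(=O)Sc1nc2ccccc2n1C1CCN(CCCC(=O)c2ccc(F)cc2)CC1`, is not yet measured. It differs from compound 2 as follows: ethoxycarbonyl in place of 2-nitrophenyl on a sulfur. Within the data shown here, the only step in hand is a 2.3-fold higher number from compound 1 to compound 2 (0.37 log units; beyond the scatter); it shows that placing the (2-nitrophenyl)sulfanyl group on the core raised the number modestly relative to the unsubstituted compound 1. Among the measured compounds shown here, no step exists for an exchange of the group on the sulfur itself, so the direction for compound 3 is not fixed by the data. Compound 3 keeps the sulfur on the aromatic carbon but carries a smaller group there, so the number is expected to lie between those of compound 1 and compound 2, somewhat nearer compound 2; the expected step is a 1.4-fold lower number from compound 2 to compound 3 (0.14 log units; within the scatter), not beyond the scatter. The estimate for compound 3 in this assay is 8 mg/kg, with a range from 3 mg/kg to 20 mg/kg.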

Compound 3, dose for half-maximal effect: 0.36 mg/kg
Beside the measured number, compound 3's estimate is 22-fold (1.35 log units) above it; the whole stated range lies above it.
By their numbers in this assay, from the lowest: compound 3; then compound 1; then compound 2.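

In this assay, the group on the sulfur, not the sulfur alone, sets the outcome at this position: ethoxycarbonyl in place of 2-nitrophenyl gives a far larger change (a 31-fold lower number from compound 2 to compound 3 (1.49 log units; beyond the scatter)) than the earlier step showed. Substitution on this aromatic carbon therefore does not always raise the number, since (ethoxycarbonyl)sulfanyl in place of hydrogen (a 13-fold lower number from compound 1 to compound 3 (1.12 log units; beyond the scatter)) runs opposite in direction to (2-nitrophenyl)sulfanyl in place of hydrogen (a 2.3-fold higher number from compound 1 to compound 2 (0.37 log units; beyond the scatter)). No evidence at hand bears on why the two sulfur-linked groups diverge so sharply.

Open, on these data alone, is whether the lower number depends on the whole ethoxycarbonyl group or on part of it, for instance how a carboxylic acid, an amide or a longer alkyl chain in place of the ethyl ester would read on the same sulfur. Also open is whether the sulfur itself is required, as the compounds shown do not tell how ethoxycarbonyl would read on the aromatic carbon without it, or how a simple methyl group would read on the sulfur.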